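Methylpyridinyl sulfonyl series: inhibition in the rat

The compounds below may be only part of what the source reports. "The series", "measured", "known", "first", "only" and "open" are said of these compounds alone.

Measured:
compound 2 `CNCc1cn(S(=O)(=O)c2cccnc2C)c(-c2cccnc2F)c1F` — 92%
compound 1 `CNCc1cn(S(=O)(=O)c2cncc(Cl)c2)c(-c2cccnc2F)c1F` — "not determined" (no result reported)

Compound 2 gives the only number shown, 92% in a functional assay on the whole organism (strain Jcl:Sprague-Dawley) for inhibition, with Rattus norvegicus as the target, with stated times of 3 min and 3 h, at a dose of 1 mg/kg by the intravenous route; a lower number here means less inhibition, a higher number more inhibition at the dose given (going by the name of the read-out). Compound 1 has no result in this assay, so no comparison between the two is available. Compound 3 `CNCc1cn(S(=O)(=O)c2cnccc2C)c(-c2cccnc2F)c1F` differs from compound 2 in one place: 4-methylpyridin-3-yl in place of 2-methylpyridin-3-yl on a sulfonyl sulfur. The two share all atoms and differ only in where the methyl sits on the pyridine that is joined to the sulfonyl sulfur. Within the data shown here, no step between measured compounds exists to calibrate such a change. Compound 3 is expected to stay close to compound 2, the step of a number 6 percentage points lower from compound 2 to compound 3 (within the scatter) estimated within the scatter, and its value in this assay estimated at 86% with a range from 62% to 98%.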

Compound 3, a percentage reported as inhibition, in the whole organism at one dose (the size of the read-out at that dose, not a potency): 98%
For compound 3 the middle estimate is 12 percentage points below the measured one; the range from low to high includes it.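

In this assay, among these compounds, the change from 2-methylpyridin-3-yl to 4-methylpyridin-3-yl on a sulfonyl sulfur gives a number 6 percentage points higher from compound 2 to compound 3 (within the scatter), the first step that can be read. Where the methyl sits on this pyridine therefore makes no difference that can be told apart from the usual scatter at this dose. Nothing measured here bears on the reason for this result.

Still open, as far as these compounds go, is whether a methoxy group or a carboxylic acid in place of the methyl would keep the read-out. Also open, from the compounds shown here alone, is whether the two methyl isomers would stay together at a lower dose.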